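Chain-lengthening of the acid arm in a bis-aryl ether series

The source may report more compounds than this note shows. Statements on the series, on what has been measured and on what is new or still open speak of the compounds shown alone.

Measured compounds:
Compound 1 `CCCc1c(OCCCCCOc2c(C(C)=O)ccc(OCC(=O)O)c2CCC)ccc(C(C)=O)c1O` — 100 nM
Compound 2 `CCCc1c(OCCCCCOc2c(C(C)=O)ccc(OCCCC(=O)O)c2CCC)ccc(C(C)=O)c1O` — 1000 nM
Compound 3 `CCCc1c(OCCOCCOc2c(C(C)=O)ccc(OCC(=O)O)c2CCC)ccc(C(C)=O)c1O` — 200 nM

The three measured compounds share two acetyl-bearing aromatic cores joined through a linker; compound 1 and compound 3 differ in that linker, and the difference between the two cores is not broken down here. In a functional assay on ileum (Cavia porcellus) for inhibition of cysteinyl leukotriene receptor (Homo sapiens) (on this read-out lower numbers stand for stronger inhibition and higher numbers for weaker inhibition), compound 1 gives 100 nM and compound 3 gives 200 nM; these two numbers sit within the scatter of each other, so no order between them is claimed. Among the compounds with values here, compound 2 gives 1000 nM in this assay, and the step of a 10-fold higher number from compound 1 to compound 2 (1.00 log units; beyond the scatter) is the one informative change in the set: 2-carboxyethyl in place of carboxy on a saturated chain carbon bound to an oxygen on an aromatic ring. It occurs twice among the compounds considered, once measured and once not.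

Compound 4 `CCCc1c(OCCOCCOc2c(C(C)=O)ccc(OCCCC(=O)O)c2CCC)ccc(C(C)=O)c1O` has not yet been measured in this assay. It stands to compound 3 as compound 2 stands to compound 1, with the same change at the same place: 2-carboxyethyl in place of carboxy on a saturated chain carbon bound to an oxygen on an aromatic ring. The expectation for compound 4 in this assay rests on the measured step of a 10-fold higher number from compound 1 to compound 2 (1.00 log units; beyond the scatter), which weakens inhibition beyond the scatter, and on compound 3 giving 200 nM as the starting point. Within the data shown here, a comparable weakening is expected for the step of a 10-fold higher number from compound 3 to compound 4 (1.00 log units; beyond the scatter), with the caveat that only one measured instance of the change exists and the linkers differ. Compound 4 is therefore estimated at 2000 nM in this assay, with a plausible range from 700 nM to 6000 nM.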

Compound 4, half-maximal inhibitory concentration: 100 nM
Compound 4: middle estimate off by 20-fold (1.30 log units), on the high side; the measured number lies below the stated range.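

The change from carboxy to 2-carboxyethyl, on a saturated chain carbon bound to an oxygen on an aromatic ring, does not carry from one core to the other with a fixed size in this assay: the same change on two cores in this assay, a 10-fold higher number (1.00 log units; beyond the scatter) from compound 1 to compound 2 and a 2.0-fold lower number (0.30 log units; within the scatter) from compound 3 to compound 4, 20-fold (1.30 log units) apart, beyond the scatter of two such steps.

With the linker of compound 3, the step reads a 2.0-fold lower number from compound 3 to compound 4 (0.30 log units; within the scatter) and gives no order between the two compounds, so the weakening seen with the linker of compound 1 does not appear on this core. This shows that a step measured on one core of this series is not a safe basis for predicting the same change on the other, but with one pair per core it does not show which feature of the linker sets the difference, or how the change would behave on any third core.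

The compounds shown leave open whether the step follows any trend across linkers, for instance with a longer all-carbon chain or with an amine in the linker. They also leave open how an acid arm of intermediate length, such as 2-carboxyethoxy, or a tetrazole in place of the carboxylic acid, would read on either core.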